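Adding a methoxy group to a biphenyl chalcone

The compounds below may be only part of what the source reports. "The series", "measured", "known", "first", "only" and "open" are said of these compounds alone.

Measured compounds:
compound 1 `COc1ccc(C(=O)/C=C/c2ccccc2-c2ccc(F)cc2)cc1OC` — 7500 nM
compound 2 `O=C(/C=C/c1ccccc1-c1ccc(F)cc1)c1cccc(O)c1` — 6900 nM
compound 3 `COc1ccc(C(=O)/C=C/c2ccccc2-c2ccc(F)cc2)cc1O` — 940 nM

Three chalcones built on the same biphenyl side have been tested in a functional assay on A549 cells (Homo sapiens) for antiproliferative activity, read by sulforhodamine B assay, with a stated time of 48 h; a lower number here means a stronger inhibitor, a higher number a weaker inhibitor. Compound 1 gives 7500 nM, compound 2 gives 6900 nM, and compound 3 gives 940 nM. The values of compound 1 and compound 2 lie within the scatter of each other; the difference between their cores is not broken down here. Compound 3 stands apart: the step of an 8.0-fold lower number from compound 1 to compound 3 (0.90 log units; beyond the scatter) is made by hydrogen in place of methyl on an oxygen on an aromatic ring, and the step of a 7.3-fold lower number from compound 2 to compound 3 (0.87 log units; beyond the scatter) is made by methoxy in place of hydrogen on an aromatic carbon.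

The unmeasured compound 4 `COc1cc(C(=O)/C=C/c2ccccc2-c2ccc(F)cc2)cc(OC)c1OC` arises from compound 1 by methoxy in place of hydrogen on an aromatic carbon. This is the same kind of change as that from compound 2 to compound 3, but not the same: there the entering group sits ortho to a hydroxy group and para to a large group, whereas here it sits ortho to a methoxy group, meta to a large group and meta to a methoxy group. The earlier step, a 7.3-fold lower number from compound 2 to compound 3 (0.87 log units; beyond the scatter), was modest but beyond the scatter. Given that the surroundings differ, compound 4 is expected to improve on compound 1 in this assay by a smaller step, a 3.0-fold lower number from compound 1 to compound 4 (0.48 log units; beyond the scatter), because the only comparable change measured is a 7.3-fold lower number from compound 2 to compound 3 (0.87 log units; beyond the scatter) and it was made in a different setting. Compound 4 is therefore estimated at 2500 nM, with a likely range from 600 nM to 10000 nM.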

Compound 4, half-maximal inhibitory concentration: 2200 nM
Estimate against measurement, compound 4: 1.1-fold (0.06 log units) above; measured number inside the range.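

In this assay, methoxy in place of hydrogen on an aromatic carbon again lowers the number, this time with a 3.4-fold lower number from compound 1 to compound 4 (0.53 log units; beyond the scatter). Set beside the earlier step, the result shows that the change carries over from one core to the other in direction, and that the two sizes cannot be told apart: the same change on two cores in this assay, a 7.3-fold lower number (0.87 log units; beyond the scatter) from compound 2 to compound 3 and a 3.4-fold lower number (0.53 log units; beyond the scatter) from compound 1 to compound 4, 2.2-fold (0.33 log units) apart, within the scatter of two such steps. Among these compounds, this does not establish a fixed gain for the change across the series: there are only two examples, the entering group has different surroundings in each, and the data neither separate any influence of those surroundings nor explain why the number falls.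

The compounds shown leave open whether another group entering at the same place, such as an ethoxy group, a chlorine atom or an amine, would lower the number as methoxy does. They also leave open whether the step would hold on a core in which the fluorine is replaced by a trifluoromethyl group or a nitrile.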